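The compounds below may be only part of what the source reports. "The series", "measured", "known", "first", "only" and "open" are said of these compounds alone.

Compound 1 `O=C(OCc1ccccc1)c1ccsc1NC(=O)[C@@H]1CCCN1`: > 250 ug/mL
Compound 2 `O=C(OCC(Cl)(Cl)Cl)c1ccsc1NC(=O)[C@@H]1CCCN1`: > 250 ug/mL

In a toxicity assay on HUVEC cells (Homo sapiens) for inhibition (a lower number here means a stronger inhibitor of growth, a higher number a weaker inhibitor of growth), compound 1 gives > 250 ug/mL, which is a limit and not a number. Compound 2 gives > 250 ug/mL, which is also a limit. Both therefore stand at the limit of > 250 ug/mL in this assay, at which 2 of the 2 values shown sit.

Compound 3 `C=CCOC(=O)c1ccsc1NC(=O)[C@@H]1CCCN1` departs from compound 1 by vinyl in place of phenyl on a saturated chain carbon bound to an oxygen next to a carbonyl group, which can also be read as benzyl to allyl. For the measured compounds named here, the only measured step at this place is a step that the two limits leave unreadable from compound 1 to compound 2, so it offers no size to carry over. No step beyond the scatter is expected in this assay, and the estimated step is a step that the limit leaves unreadable from compound 1 to compound 3. Compound 3 is expected at 300 ug/mL, within an estimated range of 150 ug/mL to 600 ug/mL.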

Compound 3, concentration for 50% growth inhibition: 149 ug/mL
Estimate against measurement, compound 3: 2.0-fold (0.30 log units) above, outside the stated range (below it).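

In this assay, for the compounds shown here, compound 3 is the first compound with a change at this place to give a number rather than a limit, 149 ug/mL. Vinyl in place of phenyl gives an at least 1.6-fold lower number from compound 1 to compound 3 (0.22 log units; that floor lies within the scatter), and vinyl in place of trichloromethyl gives an at least 1.6-fold lower number from compound 2 to compound 3 (0.22 log units; that floor lies within the scatter). Compound 1 and compound 2 both remain limits, so only a floor can be read for either step: the limit of > 250 ug/mL in this assay, at which 2 of the 3 values shown sit.

From the compounds shown here alone, the full size of both steps stays open. So does how this assay would read with an amine, a carboxylic acid or a longer chain at this place.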